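This account rests on a few compounds, and the source may have more. Where it says the series, first, only, none or still open, it means among the compounds named here.

Measured so far in an assay on cells for displacement of a labelled ligand from adenosine receptor A1 (Homo sapiens), read by scintillation counting, with a stated time of 120 min, tested at 1 uM; a lower number here means less inhibition, a higher number more inhibition at the concentration tested (going by the name of the read-out):

compound 1 `O=C(Nc1nccn2cc(-c3ccccc3)nc12)c1ccco1` — 25%
compound 2 `COc1ccc(C(=O)Nc2nc(-c3ccccc3)cn3cc(-c4ccccc4)nc23)cc1` — 6%
compound 3 `O=C(Nc1nc(-c2ccccc2)cn2cc(-c3ccccc3)nc12)c1ccc(F)cc1` — 1%

Compound 3 gives the lowest number of the three, but compound 2 lies within the scatter of it; only compound 1 stands beyond the scatter, higher. For the measured compounds named here, the one step within the shared core of compounds 2 and 3 is a number 5 percentage points lower from compound 2 to compound 3 (within the scatter), fluoro in place of methoxy on an aromatic carbon, and it tells nothing beyond the scatter.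

Compound 4 `O=C(Nc1nc(-c2ccccc2)cn2cc(-c3ccccc3)nc12)c1ccco1` is not yet measured. It differs from compound 3 by furan-2-yl in place of 4-fluorophenyl on a carbonyl carbon. Going by the values given here, no measured step bears on this change directly: compound 1 carries the same (furan-2-yl)carbonyl group, but on a core lacking one of the two phenyl groups, and no step between compound 1 and compound 3 or compound 4 is given; its value only shows that the furan amide can reach a modest number on a related core. Compound 4 is therefore expected to stay low in this assay, with a number 9 percentage points higher from compound 3 to compound 4 (within the scatter) estimated as a small rise at most, possibly none beyond the scatter. The estimate for compound 4 is 10%, in the range 0% to 30%.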

Compound 4, a percentage reported as inhibition, at one concentration (the size of the read-out at that concentration, not a potency): 10%
Estimate against measurement, compound 4: no gap at the digits printed; the range from low to high includes it.
By their numbers in this assay, from the lowest: compounds 3, 2 and 4 (each within the scatter of the next); then compound 1.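

In this assay the carbonyl carbon now carries three aromatic groups on the same core, and they are not told apart: furan-2-yl in place of 4-fluorophenyl gives a number 9 percentage points higher from compound 3 to compound 4 (within the scatter) and furan-2-yl in place of 4-methoxyphenyl gives a number 4 percentage points higher from compound 2 to compound 4 (within the scatter) in this series. For the compounds shown here, with the furan-2-yl amide held fixed, the core change can be read for the first time, and phenyl in place of hydrogen on an aromatic carbon gives a number 15 percentage points lower from compound 1 to compound 4 (beyond the scatter) as the only new step beyond the scatter. No measurement on hand accounts for either result.

Still open, going by these compounds, is whether an amine, a carboxylic acid or a longer alkyl chain in place of furan-2-yl on the carbonyl carbon would move the number beyond the scatter. Also open, on these data alone, is whether the step from hydrogen to phenyl holds with any group other than furan-2-yl on that carbonyl carbon.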